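Trifluoromethyl for Trifluoromethoxy on the Side Ring

This account rests on a few compounds, and the source may have more. Where it says the series, first, only, none or still open, it means among the compounds named here.

Measured so far, in an assay on isolated protein for inhibition of DNA topoisomerase 1 (Homo sapiens), with a stated time of 30 min, tested at 20 uM; on this read-out higher numbers stand for a stronger effect at the one concentration tested and lower numbers for a weaker effect:
Compound 1, `CCN(CC)c1ccc2nc(-c3ccccc3OC(F)(F)F)[nH]c(=O)c2c1`, gives 0%.
Compound 2, `CCN(CC)c1ccc2nc(-c3ccccc3C(F)(F)F)[nH]c(=O)c2c1`, gives 13.3%.
Compound 3, `Cc1ccc2c(=O)[nH]c(-c3cccc(OC(F)(F)F)c3)nc2c1`, gives 0%.

Compound 1 and compound 2 share one core and differ only in one group: trifluoromethyl in place of trifluoromethoxy on an aromatic carbon. That change gave a number 13.3 percentage points higher from compound 1 to compound 2 (beyond the scatter). Compound 3 carries another core; the difference between the two cores is not broken down here. Its value stands level with that of compound 1, and both together are the lowest of the three numbers.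

Compound 4, `Cc1ccc2c(=O)[nH]c(-c3cccc(C(F)(F)F)c3)nc2c1`, is not yet measured. It arises from compound 3 by trifluoromethyl in place of trifluoromethoxy on an aromatic carbon. For the measured compounds named here, this is the same kind of change as the one from compound 1 to compound 2, not the same: there the new group sat ortho to a large group, here it sits meta to a large group. Because the earlier change gave a number 13.3 percentage points higher from compound 1 to compound 2 (beyond the scatter), a step of about the same size, or somewhat smaller, is expected here, namely a number 8 percentage points higher from compound 3 to compound 4 (within the scatter) in this assay. Compound 4 is therefore estimated at 8%, most likely between 0% and 22%.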

Compound 4, a percentage reported as inhibition, at one concentration (the size of the read-out at that concentration, not a potency): 93.6%
For compound 4 the middle estimate is 85.6 percentage points below the measured one, and the stated range ends below it.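

In this assay trifluoromethyl in place of trifluoromethoxy gave a number 93.6 percentage points higher from compound 3 to compound 4 (beyond the scatter) and so moved the read-out upward on this core as well as on the core of compound 1. The two pairs differ both in the core and in where the group sits on the side ring, so they cannot tell which of these two differences matters, and two pairs make no rule for other cores. The direction of the change carried over from one core to the other, but its size did not: the same change on two cores in this assay, a number 13.3 percentage points higher (beyond the scatter) from compound 1 to compound 2 and a number 93.6 percentage points higher (beyond the scatter) from compound 3 to compound 4, 80.3 percentage points apart, beyond the scatter of two such steps

The compounds shown leave open how other groups, such as a methoxy group, a chlorine atom or a nitrile, would behave meta to a large group on the core of compound 3. They also leave open how strong the effect of compound 4 would be at other concentrations, as the read-out gives the size of its effect at the one concentration tested.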